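Compound 3 to compound 4: one added group

The source may report more compounds than this note shows. Statements on the series, on what has been measured and on what is new or still open speak of the compounds shown alone.

compound 1 `Cc1ccc(-c2cccc(NC(=O)C(Cl)Cl)c2)cc1`: 8000 nM
compound 2 `O=C(Nc1cccc(-c2ccc(C(F)(F)F)cc2)c1)C(Cl)Cl`: 33600 nM
compound 3 `O=C(Nc1cccc(-c2ccccc2)c1)C(Cl)Cl`: 20200 nM

In a functional assay on NCI-H460 cells (Homo sapiens) for cytotoxicity, read by MTT assay, with a stated time of 68 h (on this read-out lower numbers stand for stronger inhibition and higher numbers for weaker inhibition), compound 3 gives 20200 nM and cannot be told apart from compound 2 on these numbers. That pair is separated by a 1.7-fold lower number from compound 2 to compound 3 (0.22 log units; within the scatter) and is set apart from the remaining compound by a 2.5-fold higher number from compound 1 to compound 3 (0.40 log units; beyond the scatter) on one side.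

Compound 4 `COC(=O)c1ccc(-c2cccc(NC(=O)C(Cl)Cl)c2)cc1` carries one structural change methoxycarbonyl in place of hydrogen on an aromatic carbon and has methoxycarbonyl in place of hydrogen on an aromatic carbon. That same carbon holds the methyl of compound 1 and the trifluoromethyl of compound 2, so the measured steps at it bear on the change. They are small: the widest is a 4.2-fold higher number from compound 1 to compound 2 (0.62 log units; beyond the scatter) and is only modest. Neither added group raised or lowered the number in a shared direction, and methoxycarbonyl itself has not been measured. No step beyond the scatter is therefore expected, and the expected step is a 1.1-fold higher number from compound 3 to compound 4 (0.04 log units; within the scatter) in this assay.

For compound 4 the estimated value is 22000 nM with an expected range from 9000 nM to 50000 nM in this assay.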

Compound 4, half-maximal inhibitory concentration: > 50000 nM
Compound 4 ended at the assay's limit; the forecaster's own chance of this, stated with the estimate: 10%; at least 2.2-fold (0.35 log units) between middle value and limit.
By their numbers in this assay, from the lowest: compound 1; then compounds 3 and 2 (each within the scatter of the next). At a limit, above all of these: compound 4.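

In this assay, compound 4 gives no exact number, only a limit of the assay: the limit of > 50000 nM in this assay, at which 1 of the 4 values shown sits.

Methoxycarbonyl is the first group on this aromatic carbon to move the number clearly upward from hydrogen, with an at least 2.4-fold higher number from compound 3 to compound 4 (0.39 log units; beyond the scatter), and the contrast with methyl is wider, with an at least 6.2-fold higher number from compound 1 to compound 4 (0.79 log units; beyond the scatter). Against trifluoromethyl the reading is weaker, with an at least 1.4-fold higher number from compound 2 to compound 4 (0.17 log units; that floor lies within the scatter), so compound 4 cannot yet be firmly separated from compound 2.

From the compounds shown here alone, how far the true value of compound 4 lies past the limit stays open, so the full size of these steps is unknown. Also open, going by these compounds, is whether a carboxylic acid or a primary amide on the same carbon would reach the limit too, or whether this outcome belongs to methoxycarbonyl alone.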